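Replacing 2,3-dimethylphenyl with 3-fluorophenyl on an amine nitrogen

The compounds below may be only part of what the source reports. "The series", "measured", "known", "first", "only" and "open" are said of these compounds alone.

In a toxicity assay on HUVEC cells (Homo sapiens) for inhibition (on this read-out higher numbers stand for weaker inhibition of growth and lower numbers for stronger inhibition of growth), three compounds have been measured so far. Compound 1 (`Cc1nc(-c2ccccc2)c(C(=O)N2CCN(c3cccc(C)c3C)CC2)o1`) gives 0.38 ug/mL, the second highest of the three numbers. Compound 2 (`Cc1nc(-c2ccccc2F)c(C(=O)N2CCN(c3cc(Cl)cc(Cl)c3)CC2)o1`) gives 0.177 ug/mL, a lower number by a margin beyond the scatter. Compound 3 (`CCC[C@H](Nc1nc(-c2ccc(NC(=O)NCC)c(OC)c2)ncc1C)c1cccnc1`) gives 2.1 ug/mL, a higher number, also by a margin beyond the scatter.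

Compound 4 (`Cc1nc(-c2ccccc2)c(C(=O)N2CCN(c3cccc(F)c3)CC2)o1`) has not yet been measured. It keeps the core of compound 1 and carries 3-fluorophenyl in place of 2,3-dimethylphenyl on an amine nitrogen in a ring. Within the data shown here, no pair of measured compounds differs in one place only, so the data give no direct guide to this change. The highest number of the three belongs to compound 3 at 2.1 ug/mL, while compound 1 at 0.38 ug/mL and compound 2 at 0.177 ug/mL stand apart from it, and compound 4 shares much more of its structure with these two. In this assay a small step towards a higher number is therefore expected, perhaps no larger than the scatter. The estimated change is a 1.4-fold higher number from compound 1 to compound 4 (0.16 log units; within the scatter) in size. For compound 4 the expected value is 0.55 ug/mL, with an estimated range from 0.18 ug/mL to 1.6 ug/mL.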

Compound 4, concentration for 50% growth inhibition: 1.05 ug/mL
Estimate against measurement, compound 4: 1.9-fold (0.28 log units) below; low and high end bracket the measured number.
By their numbers in this assay, from the lowest: compound 2; then compound 1; then compounds 4 and 3 (each within the scatter of the next).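

In this assay, among these compounds, the pair gives the first direct reading of a change on the amine nitrogen of the six-membered ring: with the core of compound 1 kept, putting 3-fluorophenyl in place of 2,3-dimethylphenyl gives a 2.8-fold higher number from compound 1 to compound 4 (0.44 log units; beyond the scatter). This position therefore responds on this read-out, with weaker inhibition of growth by a modest margin that lies beyond the scatter, even though the group leaving and the group entering both hold one six-membered aromatic ring of carbon only, no hydrogen-bond donors or acceptors, and no net charge. Nothing at hand explains the step, and this single pair cannot separate the loss of the two methyl groups from the arrival of the fluorine.

The compounds shown leave open how an unsubstituted phenyl, a single methyl on the phenyl or a methoxyphenyl would read on this nitrogen, which could help to apportion the step. They also leave open whether the step holds on other cores, since compound 2 and compound 3 each differ from compound 1 in more than one place and cannot be read against it.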